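The source may hold more compounds than are shown below. What is called first, only, known or untested is meant among the compounds shown, and "the series" means these compounds.

Working notes on the series

Of the compounds shown here, three of the shared core have been measured in a functional assay on HeLa cells (Homo sapiens) for cytotoxicity, read by MTT assay, with a stated time of 48 h; a higher number here means a weaker inhibitor, a lower number a stronger inhibitor. Compound 1 `Cc1ccc(S(=O)(=O)/N=C(/CCNC2=CC(=O)c3ccccc3C2=O)Nc2ccc(Cl)cc2)cc1` gives 13400 nM. Compound 2 `Cc1ccc(S(=O)(=O)/N=C(/CCNC2=CC(=O)c3ccccc3C2=O)Nc2ccc(F)cc2)cc1` gives 5890 nM. Compound 3 `Cc1ccc(S(=O)(=O)/N=C(/CCNC2=CC(=O)c3ccccc3C2=O)Nc2ccccc2[N+](=O)[O-])cc1` gives 3310 nM, the lowest of the three numbers; its gap to compound 2 lies within the scatter, so no order between these two can be read, while the step of a 4.0-fold lower number from compound 1 to compound 3 (0.61 log units; beyond the scatter) lies beyond it.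

The next compound, compound 4 `Cc1ccc(S(=O)(=O)/N=C(/CCNC2=CC(=O)c3ccccc3C2=O)Nc2ccccc2I)cc1`, differs from compound 3 in one place: iodo in place of nitro on an aromatic carbon. Within the data shown here, none of the measured steps exchanges nitro for a halogen; the steps that come closest are a 2.3-fold lower number from compound 1 to compound 2 (0.36 log units; beyond the scatter), which exchanges one halogen for another on the same aromatic carbon, and a 1.8-fold lower number from compound 2 to compound 3 (0.25 log units; within the scatter), which exchanges a 4-halophenyl for 2-nitrophenyl. Both are modest or within the scatter, and all three halogen and nitro variants fall within a narrow band of numbers. The step of a 1.4-fold higher number from compound 3 to compound 4 (0.13 log units; within the scatter) is therefore expected to be small, with no direction beyond the scatter claimed. Compound 4 is estimated at 4500 nM, with a range from 1800 nM to 12000 nM, in this assay.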

Compound 4, half-maximal inhibitory concentration: 19100 nM
Compound 4: the middle estimate sits 4.2-fold (0.63 log units) below what was measured; measured number above the stated range.
By their numbers in this assay, from the lowest: compounds 3 and 2 (each within the scatter of the next); then compounds 1 and 4 (each within the scatter of the next).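

In this assay, among these compounds, the aromatic carbon that carries nitro in compound 3 proves sensitive to exchange for a halogen: iodo in place of nitro gives a 5.8-fold higher number from compound 3 to compound 4 (0.76 log units; beyond the scatter), a step the earlier compounds could not show, and one that ends the impression of a narrow band across the halogen and nitro variants. The other two steps divide the series, with 2-iodophenyl in place of 4-fluorophenyl giving a 3.2-fold higher number from compound 2 to compound 4 (0.51 log units; beyond the scatter), while 2-iodophenyl in place of 4-chlorophenyl gives a 1.4-fold higher number from compound 1 to compound 4 (0.15 log units; within the scatter), so carrying a halogen does not by itself fix where a compound falls, although both steps change the halogen and its place together and neither can separate the two. Nothing measured on these compounds beyond this read-out bears on the size of the nitro to iodo step.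

The compounds shown leave open whether the step follows from losing nitro or from introducing iodo, since iodo is the only replacement for nitro on this carbon. As far as these compounds go, how a lighter halogen, a methoxy group, an amine or a carboxylic acid on the same aromatic carbon would compare with nitro and iodo also remains open.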